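Swapping one dimethoxyphenyl group in compound 3

The source may report more compounds than this note shows. Statements on the series, on what has been measured and on what is new or still open speak of the compounds shown alone.

Values so far in a functional assay on CNE-2 cells (Homo sapiens) for antiproliferative activity, read by sulforhodamine B assay, with a stated time of 48 h (on this read-out higher numbers stand for weaker inhibition and lower numbers for stronger inhibition), are these
compound 1 `COc1cccc(/C=C/C(=O)/C=C(O)/C=C/c2cccc(OC)c2OC)c1OC` gives 12800 nM
compound 2 `COc1cccc(/C=C/C(=O)C(=Cc2ccc(F)cc2)C(=O)/C=C/c2cccc(OC)c2OC)c1OC` gives 610 nM
compound 3 `COc1ccc(C=C(C(=O)/C=C/c2cccc(OC)c2OC)C(=O)/C=C/c2cccc(OC)c2OC)cc1OC` gives 280 nM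

Compound 3 has the lowest of these numbers, which makes it the strongest inhibitor so far. Compound 4 `COc1cccc(C=C(C(=O)/C=C/c2cccc(OC)c2OC)C(=O)/C=C/c2cccc(OC)c2OC)c1OC` has the same atoms joined differently (2,3-dimethoxyphenyl in place of 3,4-dimethoxyphenyl on a double-bonded chain carbon bound to a double-bonded chain carbon), with 2,3-dimethoxyphenyl in place of 3,4-dimethoxyphenyl. Within the data shown here, the only measured step at this place (a 2.2-fold lower number from compound 2 to compound 3 (0.34 log units; beyond the scatter)) was modest and exchanged two less similar groups, so no step beyond the scatter is expected in this assay in either direction. The estimate is a 1.1-fold higher number from compound 3 to compound 4 (0.03 log units; within the scatter) and is expected to stay small. For compound 4 the estimated value is 300 nM with an expected range from 110 nM to 800 nM as the likely span.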

Compound 4, half-maximal inhibitory concentration: 400 nM
Compound 4: the middle estimate sits 1.3-fold (0.12 log units) below what was measured; measured number inside the range.
By their numbers in this assay, from the lowest: compounds 3, 4 and 2 (each within the scatter of the next, the first and the last beyond it); then compound 1.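

In this assay, rearranging the two methoxy groups gives a 1.4-fold higher number from compound 3 to compound 4 (0.15 log units; within the scatter), so 3,4-dimethoxyphenyl and 2,3-dimethoxyphenyl cannot be told apart at this place. Replacing 4-fluorophenyl with 2,3-dimethoxyphenyl gives a 1.5-fold lower number from compound 2 to compound 4 (0.18 log units; within the scatter), so this exchange, unlike the one with 3,4-dimethoxyphenyl, does not clearly separate the compounds. No available evidence explains these results. On these data alone, it remains open whether a phenyl group carrying an amine or a carboxylic acid at this place would keep the number close to these values.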